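The compounds below may be only part of what the source reports. "The series", "measured", "known", "first", "only" and "open" are said of these compounds alone.

Working notes on the series. In an assay on isolated protein (Mus musculus) for inhibition of IL15-IL15 receptor (Homo sapiens), read by resazurin assay, with stated times of 30 min and 2.5 days (a lower number here means a stronger inhibitor, a higher number a weaker inhibitor), compound 1 `Cn1c(Cc2nn(C)c(=O)c3ccccc23)nnc1SCCCCCC(=O)Nc1ccc(Cl)cc1Cl` gives 4100 nM, the higher of the two numbers in hand. Compound 3 `Cn1c(Cc2nn(C)c(=O)c3ccccc23)nnc1SCCCCCCCCCC(=O)Nc1ccc(Cl)cc1Cl` gives 2300 nM in this assay, within the scatter of compound 1. Compound 2 `CCCOc1ccc(NC(=O)CSc2nnc(Cc3nn(C)c(=O)c4ccccc34)n2C)cc1` gives in this assay only a limit, > 30000 nM (the limit of > 30000 nM in this assay, at which 1 of the 3 values shown sits). Compound 4 `Cn1c(Cc2nn(C)c(=O)c3ccccc23)nnc1SCCCCCCCC(=O)Nc1ccccc1O` differs from compound 1 in one place (2-((2-hydroxyphenyl)carbamoyl)ethyl in place of (2,4-dichlorophenyl)carbamoyl on a saturated chain carbon, five bonds along the chain from a sulfur). Within the data shown here, no step between measured compounds is available, so the size of the change from compound 1 to compound 4 can only be expected. A modest weakening, at the edge of the scatter, is estimated for the step of a 1.5-fold higher number from compound 1 to compound 4 (0.17 log units; within the scatter). Compound 4 is expected to give 6000 nM in this assay, with a range estimated from 2000 nM to 20000 nM.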

Compound 4, half-maximal inhibitory concentration: 27000 nM
Compound 4: the middle estimate sits 4.5-fold (0.65 log units) below what was measured, and the stated range ends below it.
By their numbers in this assay, from the lowest: compounds 3 and 1 (each within the scatter of the next); then compound 4. At a limit, above all of these: compound 2.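

Among these compounds, the step at this position, on a saturated chain carbon, five bonds along the chain from a sulfur, is the first readable one in this assay: a 6.6-fold higher number from compound 1 to compound 4 (0.82 log units; beyond the scatter). Among the compounds shown here, replacing (2,4-dichlorophenyl)carbamoyl with 2-((2-hydroxyphenyl)carbamoyl)ethyl therefore moves the number beyond the scatter, which the earlier compounds, with no step between them, could not show. Nothing shown bears on the cause of this step.

Still open, going by these compounds, is whether the aryl amide or the chain carries the step. On these data alone, how a carboxylic acid or an amine in place of the aryl amide would read is also open.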